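A Third Aryl Group on the Shared Core

This account rests on a few compounds, and the source may have more. Where it says the series, first, only, none or still open, it means among the compounds named here.

Measured so far:
- compound 1 `Cc1cc(Nc2cc(N3CCN(C)CC3)nc(Nc3ccc(F)cc3)n2)n[nH]1`: 680 nM
- compound 2 `COc1ccc(Nc2nc(Nc3cc(C)[nH]n3)cc(N3CCN(C)CC3)n2)cc1OC`: 678 nM

Both compounds were tested in a functional assay on HeLa cells (Homo sapiens) for antiproliferative activity, read by CCK-8 assay, with a stated time of 48 h; a higher number here means a weaker inhibitor, a lower number a stronger inhibitor. Compound 1 gives 680 nM, and compound 2 gives 678 nM. Going by the values given here, compound 2 and compound 1 thus sit side by side; the only step between them, a 1.0-fold lower number from compound 1 to compound 2 (0.00 log units; within the scatter), is within the scatter, so the two cannot be told apart.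

Compound 3 `Cc1cc(Nc2cc(N3CCN(C)CC3)nc(Nc3ccc(Cl)c(F)c3)n2)n[nH]1` has not been measured. It differs from compound 2 in one place: 4-chloro-3-fluorophenyl in place of 3,4-dimethoxyphenyl on a nitrogen on an aromatic ring. Among the compounds with values here, the one step that bears on this position, a 1.0-fold lower number from compound 1 to compound 2 (0.00 log units; within the scatter), shows that exchanging the aryl group on that nitrogen left this assay unchanged within the scatter. On that basis compound 3 is expected to show no step beyond the scatter, which is the meaning of the estimated 1.0-fold higher number from compound 2 to compound 3 (0.00 log units; within the scatter). Compound 3 is therefore estimated at 680 nM, with a range from 300 nM to 1600 nM.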

Compound 3, half-maximal inhibitory concentration: 374 nM
Compound 3: middle estimate off by 1.8-fold (0.26 log units), on the high side; the measured number falls inside the stated range.
By their numbers in this assay, from the lowest: compounds 3, 2 and 1 (each within the scatter of the next).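

Going by these compounds alone, a third aryl group on this nitrogen, 4-chloro-3-fluorophenyl, again stays within the scatter in this assay, with a 1.8-fold lower number from compound 2 to compound 3 (0.26 log units; within the scatter) and a 1.8-fold lower number from compound 1 to compound 3 (0.26 log units; within the scatter) as the two steps to the earlier compounds. The position has now carried three different aryl groups with no step beyond the scatter, even though the 3,4-dimethoxyphenyl group counts 2 hydrogen-bond acceptors and the 4-chloro-3-fluorophenyl group counts 0. No accompanying measurement offers an explanation for this result.

The compounds shown leave open whether this tolerance extends past substituted phenyl rings, for example to a phenyl ring carrying a carboxylic acid or an amine, or to a plain alkyl chain on the nitrogen. They also say nothing about changes elsewhere on the shared core, since every other part stays the same across all three compounds.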